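The source may hold more compounds than are shown below. What is called first, only, known or untested is meant among the compounds shown, and "the series" means these compounds.

Compound 1, `COc1ccc(-c2cnc(NC(=O)c3cccc(O)c3)n2C)cc1`: > 100000 nM in a toxicity assay on THP-1 cells (Homo sapiens) for inhibition; on this read-out higher numbers stand for lower toxicity in this test and lower numbers for higher toxicity in this test
Compound 2, `COc1ccc(-c2cnc(NC(=O)c3ccccc3F)n2C)cc1`: > 100000 nM in this assay

Compound 1 gives only a limit of this assay, not a number. Compound 2 likewise gives only a limit, so it stands at the top of what this assay reports, where (the limit of > 100000 nM in this assay, at which 2 of the 2 values shown sit). Within the data shown here, the single measured step, a step that the two limits leave unreadable from compound 1 to compound 2, is the one that bears on compound 3, `COc1ccc(-c2cnc(NC(=O)C3CCCC3)n2C)cc1`, and its size is not readable. The change is cyclopentyl in place of 2-fluorophenyl on a carbonyl carbon. The step expected is a number no higher from compound 2 to compound 3 (the limit leaves the size open), nothing beyond the scatter. Compound 3 is therefore estimated at 100000 nM, between 50000 nM and 300000 nM.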

Compound 3, half-maximal cytotoxic concentration: > 100000 nM
Compound 3 was reported as a limit; the forecaster's own chance of this, stated with the estimate: 85%; the middle value sits exactly at the limit.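

Compound 3 gives only a limit, as do compound 1 and compound 2, so no step among these three can be read: the limit of > 100000 nM in this assay, at which 3 of the 3 values shown sit. The compounds shown leave open whether any of these changes on the carbonyl carbon alters the result in this assay.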